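The source may report more compounds than this note shows. Statements on the series, on what has been measured and on what is new or still open speak of the compounds shown alone.

Measured so far in a functional assay on PC-3 cells (Homo sapiens) for inhibition, read by MTT assay, with a stated time of 48 h; on this read-out higher numbers stand for weaker inhibition of growth and lower numbers for stronger inhibition of growth:
- Compound 1 `CN1CC[C@H](c2c(O)cc(O)c3c(=O)cc(/C=C/c4cccc(Cl)c4)oc23)[C@H](O)C1`: 10000 nM
- Compound 2 `CN1CC[C@H](c2c(O)cc(O)c3c(=O)cc(/C=C/c4cccc(F)c4)oc23)[C@H](O)C1`: 7000 nM

Compound 2 has no clear rank of its own. Going by the values given here, the only comparison available is a 1.4-fold lower number from compound 1 to compound 2 (0.15 log units; within the scatter), so the two compounds cannot be told apart in this assay.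

In compound 3 `CN1CC[C@H](c2c(O)cc(O)c3c(=O)cc(/C=C/c4ccccc4F)oc23)[C@H](O)C1`, 2-fluorophenyl stands in place of 3-fluorophenyl on a double-bonded chain carbon bound to a double-bonded chain carbon. The two compounds have the same atoms, joined differently: 2-fluorophenyl in place of 3-fluorophenyl on a double-bonded chain carbon bound to a double-bonded chain carbon.

That one measured step bears on this change only loosely. Among the compounds with values here, it puts fluoro in place of chloro on an aromatic carbon, and no measured pair shows what moving the fluoro group does. Within the data shown here, with only that small step as a guide, no change beyond the scatter is expected, in either direction. The expected step is no change at the digits printed from compound 2 to compound 3 (within the scatter). Compound 3 is estimated at 7000 nM, with an expected range of 3500 nM to 14000 nM.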

Compound 3, concentration for 50% growth inhibition: 20000 nM
Estimate against measurement, compound 3: 2.9-fold (0.46 log units) below, outside the stated range (above it).
By their numbers in this assay, from the lowest: compounds 2, 1 and 3 (each within the scatter of the next, the first and the last beyond it).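

In this assay, going by these compounds alone, moving the fluoro group gives a 2.9-fold higher number from compound 2 to compound 3 (0.46 log units; beyond the scatter) and so provides the first step that lies beyond the scatter. At this place, on a double-bonded chain carbon bound to a double-bonded chain carbon, 2-fluorophenyl and 3-fluorophenyl therefore cannot be treated as equivalent, even though they contain the same atoms, whereas the change from 3-chlorophenyl to 2-fluorophenyl, a 2.0-fold higher number from compound 1 to compound 3 (0.30 log units; within the scatter), cannot be told apart from repeat-measurement noise. Nothing available here explains why the two fluorophenyl groups differ.

The compounds shown leave open whether 2-chlorophenyl would follow 2-fluorophenyl or whether the step belongs to fluoro alone. They also leave open how an unsubstituted phenyl or a methoxyphenyl would compare at this place.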